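Cyclic carbamate series: aryl amine replaces aryl ether

The source may report more compounds than this note shows. Statements on the series, on what has been measured and on what is new or still open speak of the compounds shown alone.

Measured so far:
compound 1 `CC1(COC(=O)N2CC3COCC(C2)C3Oc2ncnc(Nc3ccc(C#N)cc3Cl)c2F)COC1` gives 516 nM
compound 2 `CC1(OC(=O)N2CC3COCC(C2)C3Oc2ncnc(Oc3ccccc3F)c2F)CC1` gives 75 nM
compound 3 `CC1(OC(=O)N2C[C@H]3COC[C@@H](C2)[C@@H]3Oc2ncnc(Nc3c(F)cccc3F)c2F)CC1` gives 113 nM

All three numbers come from a functional assay for agonist activity at Glucose-dependent insulinotropic receptor (Mus musculus), read by cAMP accumulation; a lower number here means that less compound is needed, a higher number that more compound is needed for the effect. Compound 2 stands at the lowest number of the three, but compound 3 lies within the scatter of it, so no order between compound 2 and compound 3 can be read from these two values; only compound 1 sits clearly apart from compound 2, at a higher number, and compound 1 also differs from compound 2 in more than one place.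

Compound 4 `CC1(OC(=O)N2CC3COCC(C2)C3Oc2ncnc(Nc3cccnc3Cl)c2F)CC1` has not yet been measured. It carries the same cap as compound 2 and differs from it in one place: (2-chloropyridin-3-yl)amino in place of 2-fluorophenoxy on an aromatic carbon. Among the compounds with values here, no single-change step between measured compounds is available to size this exchange. The nearest comparison, compound 2 against compound 3, shows an aryl amine and an aryl ether on the shared core within the scatter of each other, so the change in compound 4 is expected to move the number in this assay by a small amount, if at all, probably toward a higher number, a 2.0-fold higher number from compound 2 to compound 4 (0.30 log units; within the scatter). Compound 4 is therefore estimated at 150 nM, with a range from 50 nM to 500 nM.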

Compound 4, half-maximal effective concentration: 58 nM
Compound 4: the middle estimate sits 2.6-fold (0.41 log units) above what was measured, within the range that was stated.
By their numbers in this assay, from the lowest: compounds 4, 2 and 3 (each within the scatter of the next); then compound 1.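

In this assay, (2-chloropyridin-3-yl)amino in place of 2-fluorophenoxy on this aromatic carbon gives a 1.3-fold lower number from compound 2 to compound 4 (0.11 log units; within the scatter). Within the data shown here, this is the first single-change step, and it shows that the position tolerates this exchange of both the linking atom and the aromatic ring, with no readable shift in the number. Nothing measured here bears on why the number holds.

The step changes the linking atom and the ring together, so it leaves open what each contributes alone; (2-chlorophenyl)amino or (2-chloropyridin-3-yl)oxy on the shared core would separate the two. Also open, on these data alone, is whether this aromatic carbon tolerates a non-aromatic amine such as morpholine, since both groups compared here carry a six-membered aromatic ring.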